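This account rests on a few compounds, and the source may have more. Where it says the series, first, only, none or still open, it means among the compounds named here.

Working notes on the series. In a functional assay on MCF7 cells (Homo sapiens) for cytotoxicity, read by CellTiter-Glo, with a stated time of 5 days (on this read-out higher numbers stand for weaker inhibition and lower numbers for stronger inhibition), compound 1 `CC/C(=C(/c1ccc(/C=C/C(=O)O)cc1)c1ccc2[nH]ncc2c1)c1cccc(Cl)c1` gives 12 nM and compound 2 `CC/C(=C(/c1ccc(/C=C/C(=O)O)cc1)c1ccc2[nH]ncc2c1)c1ccccc1C` gives 4 nM. Compound 2 therefore holds the lower of the two numbers, with a gap beyond the usual scatter. The next compound is compound 3 `CC/C(=C(/c1ccc(/C=C/C(=O)O)cc1)c1ccc2[nH]ncc2c1)c1ccccc1S(C)(=O)=O`, and the change is methylsulfonyl in place of methyl on an aromatic carbon. In words, this is methylsulfonyl in place of methyl on an aromatic carbon, ortho to a large group.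

Within the data shown here, only one measured step bears on this change: a 3.0-fold lower number from compound 1 to compound 2 (0.48 log units; beyond the scatter). It is modest in size and involves the same phenyl group, with 2-methylphenyl in place of 3-chlorophenyl. Among the measured compounds shown here, no measured compound carries methylsulfonyl, so the data give no direct reading for this group. A step of similar or somewhat larger size is expected, toward a higher number in this assay, starting from the 4 nM of compound 2. The expected step is a 3.8-fold higher number from compound 2 to compound 3 (0.57 log units; beyond the scatter), and its size remains uncertain. For compound 3 the estimated value is 15 nM, with an expected range of 4 nM to 60 nM.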

Compound 3, half-maximal inhibitory concentration: 70 nM
Compound 3: the middle estimate sits 4.7-fold (0.67 log units) below what was measured; the whole stated range lies below it.
By their numbers in this assay, from the lowest: compound 2; then compound 1; then compound 3.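

In this assay, among these compounds, the group on this aromatic carbon, ortho to a large group, proves far from interchangeable: methylsulfonyl in place of methyl gives an 18-fold higher number from compound 2 to compound 3 (1.24 log units; beyond the scatter) and is the largest step seen so far. The change of phenyl group also gives a 5.8-fold higher number from compound 1 to compound 3 (0.77 log units; beyond the scatter) in the comparison with 3-chlorophenyl, so the order by number now runs from 2-methylphenyl through 3-chlorophenyl to 2-(methylsulfonyl)phenyl, a much wider span than the first pair showed. Nothing in hand accounts for the rise in number on going from methyl to methylsulfonyl.

Whether the higher number belongs to methylsulfonyl alone or extends to other groups on this carbon stays open, since ethyl, methoxy and an amine are not among the compounds shown. Also open, from the compounds shown here alone, is whether the step keeps its size on the other parts of the shared core, for instance with a primary amide in place of the carboxylic acid.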